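This account rests on a few compounds, and the source may have more. Where it says the series, first, only, none or still open, it means among the compounds named here.

Measured so far: compound 1 `O=C(Nc1cccc(/C=C/C(=O)c2nc3ccccc3[nH]2)c1)c1cccc(C(F)(F)F)c1` with 3360 nM in a functional assay on HCT-116 cells (Homo sapiens) for antiproliferative activity, read by MTT assay, with a stated time of 48 h (on this read-out higher numbers stand for weaker inhibition and lower numbers for stronger inhibition), and compound 2 `COc1cccc(C(=O)Nc2cccc(/C=C/C(=O)c3nc4ccccc4[nH]3)c2)c1` with 3680 nM in this assay.

Among the measured compounds shown here, compound 2 and compound 1 lie within the scatter of each other; the one measured step, a 1.1-fold higher number from compound 1 to compound 2 (0.04 log units; within the scatter), exchanged the group on the aromatic carbon and left the number essentially unchanged. Compound 3 `COc1ccc(C(=O)Nc2cccc(/C=C/C(=O)c3nc4ccccc4[nH]3)c2)cc1` differs from compound 2 by 4-methoxyphenyl in place of 3-methoxyphenyl on a carbonyl carbon. For the measured compounds named here, no measured step tests this move of the methoxy group, so the expectation rests only on the flat step from compound 1 to compound 2. Compound 3 is therefore expected to show a 1.0-fold higher number from compound 2 to compound 3 (0.00 log units; within the scatter), nothing beyond the scatter. The estimate for compound 3 is 3700 nM, between 1800 nM and 7500 nM.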

Compound 3, half-maximal inhibitory concentration: 4880 nM
Beside the measured number, compound 3's estimate is 1.3-fold (0.12 log units) below it, and the stated range covers the measured number.
By their numbers in this assay, from the lowest: compounds 1, 2 and 3 (each within the scatter of the next).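

In this assay the exchange of 3-methoxyphenyl for 4-methoxyphenyl on the carbonyl carbon gave a 1.3-fold higher number from compound 2 to compound 3 (0.12 log units; within the scatter) and so showed that moving the methoxy group did not shift the number beyond the scatter. Putting 4-methoxyphenyl in place of 3-(trifluoromethyl)phenyl gave a 1.5-fold higher number from compound 1 to compound 3 (0.16 log units; within the scatter) and left all three groups at this place within the scatter of one another. Nothing available explains this flatness. From the compounds shown here alone, whether an amine or a carboxylic acid on this aromatic ring would move the number beyond the scatter stays open.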